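Amidating the acid chain of compound 3: an estimate

The compounds below may be only part of what the source reports. "The series", "measured", "known", "first", "only" and "open" are said of these compounds alone.

Measured in a functional assay on HCT-116 cells (Homo sapiens) for antiproliferative activity, read by sulforhodamine B assay, with a stated time of 72 h; on this read-out lower numbers stand for stronger inhibition and higher numbers for weaker inhibition:
- Compound 1 `Cn1ncc(Cl)c1-c1cc(C(=O)N[C@H]2CNCC[C@@H]2c2ccc(C(F)(F)F)cc2)oc1Cl`: 1050 nM
- Compound 2 `O=C(N[C@@H]1CNCC[C@H]1c1ccc(Cl)cc1)c1ccc(-c2ncnc3c2CCC3O)s1`: 23000 nM
- Compound 3 `Cn1ncc(Cl)c1-c1cc(C(=O)N[C@@H]2CN[C@H](CC(=O)O)C[C@H]2c2ccc(Cl)c(Cl)c2)oc1Cl`: 4020 nM

Among these three, compound 3 holds the second highest number in this assay. Its nearest neighbour is compound 1, whose number is lower by more than the usual scatter, while compound 2 lies further off with a higher number, again beyond the scatter.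

Compound 4 `Cn1ncc(Cl)c1-c1cc(C(=O)N[C@@H]2CN[C@H](CC(=O)NCC(O)CO)C[C@H]2c2ccc(Cl)c(Cl)c2)oc1Cl` keeps the whole of compound 3 except at the end of the carboxymethyl chain. The change is (2,3-dihydroxypropyl)amino in place of hydroxy on a carbonyl carbon; read one bond further out, carboxy becomes (2,3-dihydroxypropyl)carbamoyl. Among the measured compounds shown here, no step between two measured compounds matches this change, so there is no direct precedent here.

In this assay compound 4 is expected to give 2200 nM, with a likely range from 700 nM to 7000 nM. This estimate means a modest step toward a lower number, a 1.8-fold lower number from compound 3 to compound 4 (0.26 log units; within the scatter), close to the edge of the scatter rather than clearly beyond it.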

Compound 4, half-maximal inhibitory concentration: 7090 nM
For compound 4 the middle estimate is 3.2-fold (0.51 log units) below the measured one, outside the stated range (above it).
By their numbers in this assay, from the lowest: compound 1; then compounds 3 and 4 (each within the scatter of the next); then compound 2.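

In this assay, putting (2,3-dihydroxypropyl)amino in place of hydroxy on this carbonyl carbon gives a 1.8-fold higher number from compound 3 to compound 4 (0.25 log units; within the scatter). Among the compounds shown here, this is the first reading at this position, and it shows that the carboxylic acid can give way to an amide, with 6 heavy atoms entering where 1 leaves, without a shift beyond the usual scatter of the read-out. Nothing available accounts for this result, so the two compounds can only be described as reading alike.

Going by these compounds, a single replacement cannot show whether this tolerance is general, so it remains open whether a simple methylamino group, a morpholine ring or a longer chain ending in an amine would also read alike. Also open, on these data alone, is whether any group at this carbonyl carbon could move the number clearly away from that of compound 3.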